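Series notes: aryl variation on the shared core

The source may report more compounds than this note shows. Statements on the series, on what has been measured and on what is new or still open speak of the compounds shown alone.

Measured compounds in a functional assay on KB cells (Homo sapiens) for antiproliferative activity, read by sulforhodamine B assay, with a stated time of 3 days; on this read-out lower numbers stand for an effect already at smaller amounts and higher numbers for an effect only at larger amounts of compound:
compound 1, `CCC1=C(O)c2c(oc(-c3cccc(OC)c3)cc2=O)C(CC)(CC)C1=O`: 13.3 uM
compound 2, `CCC1=C(O)c2c(oc(-c3cccc(OC(F)(F)F)c3)cc2=O)C(CC)(CC)C1=O`: the reading is a limit, > 47.4 uM
compound 3, `CCC1=C(O)c2c(oc(-c3ccc(OC)c(OC)c3)cc2=O)C(CC)(CC)C1=O`: 14.7 uM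

Compound 1 stands lowest of the two numbers available; compound 3 sits within the scatter of it, and the value of compound 2 is a limit of this assay rather than a number, one of the three readings sitting at the limit of > 47.4 uM in this assay, at which 1 of the 3 values shown sits.

Compound 4, `CCC1=C(O)c2c(oc(-c3cccc(C)c3C)cc2=O)C(CC)(CC)C1=O`, is not yet measured. It differs from compound 1 by 2,3-dimethylphenyl in place of 3-methoxyphenyl on an aromatic carbon.

Two measured steps leave from compound 1. Putting trifluoromethyl in place of methyl on the ring oxygen gave an at least 3.5-fold higher number from compound 1 to compound 2 (0.55 log units; beyond the scatter). Adding a methoxy on an aromatic carbon gave a 1.1-fold higher number from compound 1 to compound 3 (0.04 log units; within the scatter). Neither step removes the methoxy group itself, so the change in compound 4 is not directly covered; the steps show only that a modest alteration of this aryl ring can leave the number unchanged or can push it past the limit of this assay.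

For compound 4 a step near a 1.5-fold higher number from compound 1 to compound 4 (0.18 log units; within the scatter) is expected, with the number likely no lower than that of compound 1. Compound 4 is estimated at 20 uM, within 7 uM to 60 uM.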

Compound 4, concentration for half-maximal effect: 3.1 uM
Compound 4: middle estimate off by 6.5-fold (0.81 log units), on the high side; the whole stated range lies above it.
By their numbers in this assay, from the lowest: compound 4; then compounds 1 and 3 (each within the scatter of the next). At a limit, above all of these: compound 2.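

In this assay, 2,3-dimethylphenyl in place of 3-methoxyphenyl on this aromatic carbon gives a 4.3-fold lower number from compound 1 to compound 4 (0.63 log units; beyond the scatter) and is the only step shown that lowers the number beyond the scatter. The earlier steps shown here showed this aryl ring only leaving the number unchanged or reaching a limit, whereas this change shows that the number can also fall when the substituents on the ring are exchanged. It also shows that the methoxy oxygen of compound 1 is not required for activity in this range, since compound 4, whose aryl group holds carbon only, gives 3.1 uM and nothing measured here accounts for the size of the step.

The compounds shown do not separate the contributions of the two methyl groups of compound 4, so it stays open whether one of them alone would give the same lower number or whether both are needed. Going by these compounds, it also stays open whether a larger group such as ethyl, or an amine or a hydroxyl group, in place of either methyl would keep the number near that of compound 4.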